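Methyl in place of chloro: compound 1 to compound 4

The source may report more compounds than this note shows. Statements on the series, on what has been measured and on what is new or still open speak of the compounds shown alone.

Compound 1 `Cc1nc(N(C)c2ccc([Se]C#N)c(Cl)c2)c2ccccc2n1` gives 12 nM in a functional assay on LoVo cells (Homo sapiens) for inhibition, read by MTT assay, with a stated time of 48 h; on this read-out higher numbers stand for weaker inhibition and lower numbers for stronger inhibition. Among the three numbers it stands second highest: compound 3 `COc1ccc(N(C)c2nc(C)nc3ccccc23)cc1[Se]C` gives 3 nM, a lower number beyond the scatter, while compound 2 `COc1ccc(N(C)c2nc(C)nc3ccccc23)cc1OCCCC[Se]C#N` gives 882 nM, far higher. Among the measured compounds shown here, the only single-point step measured so far is a 290-fold lower number from compound 2 to compound 3 (2.47 log units; beyond the scatter), and it concerns a different group elsewhere on the shared core. Compound 4 `Cc1nc(N(C)c2ccc([Se]C#N)c(C)c2)c2ccccc2n1` differs from compound 1 by methyl in place of chloro on an aromatic carbon. For the measured compounds named here, no measured step bears on an exchange of chloro for methyl, so the expectation rests on the small size of the change: a step of no more than the scatter is expected, a 1.3-fold higher number from compound 1 to compound 4 (0.10 log units; within the scatter). Compound 4 is therefore estimated at 15 nM, within 5 nM to 45 nM.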

Compound 4, half-maximal inhibitory concentration: 19 nM
Compound 4: middle estimate off by 1.3-fold (0.10 log units), on the low side, and the stated range covers the measured number.
By their numbers in this assay, from the lowest: compound 3; then compounds 1 and 4 (each within the scatter of the next); then compound 2.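

In this assay, among the compounds shown here, the step of a 1.6-fold higher number from compound 1 to compound 4 (0.20 log units; within the scatter) is the first reading at this aromatic carbon, and it shows that methyl can take the place of chloro without a change beyond the scatter. The exchange keeps the count of heavy atoms unchanged and leaves the number in the low range set by compound 1. Nothing available accounts for this result. Open, on these data alone, is whether an amine, a carboxylic acid or a longer chain at this carbon would keep the number there. Also open, as far as these compounds go, is whether the same exchange behaves alike on other groups of the shared core.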